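Three thiophene-fused amides and a dichlorophenyl thiourea

The compounds below may be only part of what the source reports. "The series", "measured", "known", "first", "only" and "open" are said of these compounds alone.

Measured so far in a functional assay on MKN-74 cells (Homo sapiens) for antiproliferative activity, with a stated time of 24 h; on this read-out lower numbers stand for stronger inhibition and higher numbers for weaker inhibition:
- compound 1, `NC(=O)c1c(NC(=O)c2ccccc2Cl)sc2c1CCN(Cc1ccccc1F)C2`: 12900 nM
- compound 2, `NC(=O)c1c(NC(=O)c2ccccc2Cl)sc2c1CCN(C(=S)Nc1ccccc1)C2`: 15600 nM
- compound 3, `NC(=O)c1c(NC(=O)c2ccccc2Cl)sc2c1CCN(C(=S)Nc1ccccc1Br)C2`: 10800 nM

All three share one core and differ only in the group on the amine nitrogen in the ring. Compound 3 gives the lowest of the three numbers, but this position means little: from compound 1 it is a 1.2-fold lower number from compound 1 to compound 3 (0.08 log units; within the scatter), and from compound 2 it is a 1.4-fold lower number from compound 2 to compound 3 (0.16 log units; within the scatter), so the three values cannot be told apart.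

Compound 4, `NC(=O)c1c(NC(=O)c2ccccc2Cl)sc2c1CCN(C(=S)Nc1c(Cl)cccc1Cl)C2`, is not yet measured. It keeps the thiourea of compound 3 and changes the ring on its far side: 2,6-dichlorophenyl in place of 2-bromophenyl on an amide-type nitrogen. Within the data shown here, the only step that touches this part of the molecule is the one from compound 2 to compound 3, where bromo in place of hydrogen gave a 1.4-fold lower number from compound 2 to compound 3 (0.16 log units; within the scatter). One substituent change on that ring therefore did nothing beyond the scatter, and the exchange of halogens on the same ring is expected to behave alike. For compound 4 the expected step is a 1.1-fold lower number from compound 3 to compound 4 (0.03 log units; within the scatter), so in this assay compound 4 is estimated at 10000 nM, with a range from 4000 nM to 25000 nM.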

Compound 4, half-maximal inhibitory concentration: 4020 nM
Beside the measured number, compound 4's estimate is 2.5-fold (0.40 log units) above it; the measured number falls inside the stated range.
By their numbers in this assay, from the lowest: compound 4; then compounds 3, 1 and 2 (each within the scatter of the next).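

In this assay, among these compounds, the ring on the far side of the thiourea is the first part of these molecules where a change moves the number beyond the scatter: 2,6-dichlorophenyl in place of 2-bromophenyl on the amide-type nitrogen gives (a 2.7-fold lower number from compound 3 to compound 4 (0.43 log units; beyond the scatter)), and in place of phenyl it gives (a 3.9-fold lower number from compound 2 to compound 4 (0.59 log units; beyond the scatter)), whereas the single bromo alone stayed within the scatter (a 1.4-fold lower number from compound 2 to compound 3 (0.16 log units; within the scatter)). The step from the benzyl-type group of compound 1 is also beyond the scatter (a 3.2-fold lower number from compound 1 to compound 4 (0.51 log units; beyond the scatter)), so compound 4 is the most potent of the four here, though all three steps are modest in size. Nothing among the data shown accounts for this step.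

The compounds shown leave open whether the lower number depends on having two substituents on this ring or on chlorine itself, a question that a ring with a single chlorine, or one carrying two bromines or two methyl groups, would address. They also leave open whether the sulfur of the thiourea matters, which the matching urea, with oxygen in its place, would test.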